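Fluoro at the pyridine carbon of an aminoamidine thiosemicarbazide

The compounds below may be only part of what the source reports. "The series", "measured", "known", "first", "only" and "open" are said of these compounds alone.

Compound 1 `N/C(=N\NC(=S)N1CCCCCC1)c1ccccn1` is the stronger of the two compounds measured here. In a functional assay on A-431 cells (Homo sapiens) for cytotoxicity, read by MTT assay, with a stated time of 72 h (a lower number here means a stronger inhibitor, a higher number a weaker inhibitor), compound 1 gives 3000 nM, the lowest number among the compounds measured, while compound 2 `Cc1ccnc(/C(N)=N/NC(=S)N2CCCCCC2)c1` gives 8000 nM. Among the measured compounds shown here, the single measured step, a 2.7-fold higher number from compound 1 to compound 2 (0.43 log units; beyond the scatter), shows that adding a methyl group on the aromatic carbon weakens the inhibition modestly.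

Compound 3 `N/C(=N\NC(=S)N1CCCCCC1)c1ccc(F)cn1` differs from compound 1 by fluoro in place of hydrogen on an aromatic carbon. For the measured compounds named here, the only step that bears on this change is the methyl one, a 2.7-fold higher number from compound 1 to compound 2 (0.43 log units; beyond the scatter); fluoro is a smaller group than methyl and sits at a different aromatic carbon, so that step is at best a loose guide. The author therefore expects the change from compound 1 to compound 3 to shift the number by little, if at all, beyond the scatter, with a slight lean toward a higher number, giving an expected step of a 1.3-fold higher number from compound 1 to compound 3 (0.12 log units; within the scatter). Compound 3 is estimated to give 4000 nM in this assay, within a range from 1500 nM to 11000 nM.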

Compound 3, half-maximal inhibitory concentration: 1000 nM
For compound 3 the middle estimate is 4.0-fold (0.60 log units) above the measured one; measured number outside the range, below it.
By their numbers in this assay, from the lowest: compound 3; then compound 1; then compound 2.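

In this assay, fluoro in place of hydrogen on the aromatic carbon two atoms from the ring nitrogen and para to a large group gives a 3.0-fold lower number from compound 1 to compound 3 (0.48 log units; beyond the scatter). This shows that a substituent at this position can lower the number beyond the scatter, whereas the earlier step, a 2.7-fold higher number from compound 1 to compound 2 (0.43 log units; beyond the scatter), had shown only a rise, with methyl at a different aromatic carbon, so a substituent on this ring does not always raise the number; however, those two steps differ in both the group and its place, and they cannot show which of the two sets their direction. Nothing given here accounts for the lower number with fluoro.

Fluoro is the only group shown at this carbon, so it remains open whether the lower number is specific to fluoro or would also appear with chloro, methoxy or an amine there. Going by these compounds, it is also open whether fluoro would lower the number at the aromatic carbon that carries the methyl group in compound 2.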